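The source may hold more compounds than are shown below. What is called first, only, known or untested is meant among the compounds shown, and "the series" means these compounds.

Three nucleosides sharing one core have been tested in a functional assay on HL-60 cells (Homo sapiens) for antiproliferative activity, read by XTT assay, with a stated time of 72 h; on this read-out lower numbers stand for stronger inhibition and higher numbers for weaker inhibition. Compound 1 `COc1nc(N)nc2c1c(-c1cc3ccccc3o1)cn2[C@@H]1O[C@H](CO)[C@@H](O)[C@H]1O` gives only a limit of the assay, > 20000 nM. Compound 3 `O=c1[nH]cnc2c1c(-c1cccs1)cn2[C@@H]1O[C@H](CO)[C@@H](O)[C@H]1O` likewise gives only a limit, > 20000 nM. Compound 2 `Nc1nc2c(c(-c3ccccc3)cn2[C@@H]2O[C@H](CO)[C@@H](O)[C@H]2O)c(=O)[nH]1` also reaches no number in this assay, but only the limit > 20000 nM. Where compound 2 stands is therefore simply at the limit of > 20000 nM in this assay, at which 3 of the 3 values shown sit, together with every other value on hand, so no ordering among the three can be drawn.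

Compound 4 `Nc1nc2c(c(-c3ccsc3)cn2[C@@H]2O[C@H](CO)[C@@H](O)[C@H]2O)c(=O)[nH]1` has not been measured. It differs from compound 2 in one place: thiophen-3-yl in place of phenyl on an aromatic carbon. Among the compounds with values here, no step between measured compounds is available to judge this change. Within the data shown here, with every value so far sitting at the limit, the step from compound 2 to compound 4 in this assay is expected to be none beyond the scatter, which for compound 4 means a step that the limit leaves unreadable from compound 2 to compound 4. Compound 4 is accordingly estimated at 25000 nM, within a range from 10000 nM to 60000 nM, most probably reported again only as a limit.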

Compound 4, half-maximal inhibitory concentration: > 20000 nM
Compound 4 was reported as a limit; the forecaster's own chance of this, stated with the estimate: 85%; the middle value is on the limit's open side.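

No step can be read from compound 2 to compound 4, as both stand only at a limit: the limit of > 20000 nM in this assay, at which 4 of the 4 values shown sit. The compounds shown leave open how thiophen-3-yl and phenyl compare, and whether any group on the shared core gives a measurable value in this assay.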